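This account rests on a few compounds, and the source may have more. Where it says the series, first, only, none or still open, it means among the compounds named here.

The measured compounds:
Compound 1, `O=C(CCCCCCc1ccccn1)c1ncc(-c2ccccn2)o1`: in an assay for inhibition of Fatty-acid amide hydrolase 1 (Rattus norvegicus) (on this read-out higher numbers stand for weaker inhibition and lower numbers for stronger inhibition), compound 1 gives 120 nM.
Compound 2, `O=C(O)c1cccc(CCCCCCC(=O)c2ncc(-c3ccccn3)o2)c1`: compound 2 gives > 600 nM, which is a limit of the assay and not a number.
Compound 3, `CS(=O)(=O)c1cccc(CCCCCCC(=O)c2ncc(-c3ccccn3)o2)c1`: compound 3 gives 1.3 nM.

Compound 3 holds the lowest of the two numbers shown, the nearest being compound 1, whose number is higher by an at least 5.0-fold higher number from compound 1 to compound 2 (0.69 log units; beyond the scatter) -sized steps of a different kind, and the gap to compound 1 lies beyond the scatter. Compound 4 is `CSc1cccc(CCCCCCC(=O)c2ncc(-c3ccccn3)o2)c1`; it differs from compound 3 in one place: methylsulfanyl in place of methylsulfonyl on an aromatic carbon. Within the data shown here, two measured steps bear on this. Exchanging pyridin-2-yl for 3-carboxyphenyl gave an at least 5.0-fold higher number from compound 1 to compound 2 (0.69 log units; beyond the scatter), and exchanging carboxy for methylsulfonyl gave an at least 460-fold lower number from compound 2 to compound 3 (2.66 log units; beyond the scatter), where compound 2 sits at the limit of > 600 nM in this assay, at which 1 of the 3 values shown sits. Both show that the group on this ring matters greatly. Removing the two oxygens of the methylsulfonyl is expected to cost potency, giving a 31-fold higher number from compound 3 to compound 4 (1.49 log units; beyond the scatter). Compound 4 is therefore estimated at 40 nM, with a range from 8 nM to 200 nM.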

Compound 4, inhibition constant: 4.2 nM
The estimate for compound 4 lay 9.5-fold (0.98 log units) above the measured number; measured number below the stated range.
By their numbers in this assay, from the lowest: compound 3; then compound 4; then compound 1. At a limit, above all of these: compound 2.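

Removing the two oxygens of the methylsulfonyl changes this assay only modestly, with a 3.2-fold higher number from compound 3 to compound 4 (0.51 log units; beyond the scatter), so much of the strength survives when methylsulfanyl takes this place on the aromatic ring. Compound 4 also keeps a large lead over the pyridin-2-yl of the core of compound 1, with a 29-fold lower number from compound 1 to compound 4 (1.46 log units; beyond the scatter), which shows that this lead does not require the sulfonyl oxygens. Against carboxy the step is also large, with an at least 140-fold lower number from compound 2 to compound 4 (2.15 log units; beyond the scatter), but its size is only a bound, since the value of compound 2 is a limit and not a number: the limit of > 600 nM in this assay, at which 1 of the 4 values shown sits.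

On these data alone, what an amine or a methoxy group on the same aromatic carbon would give remains open. So does whether methylsulfanyl would hold its number on a longer chain.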